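This account rests on a few compounds, and the source may have more. Where it says the series, first, only, none or still open, it means among the compounds named here.

Compound 1 `c1cncc(-c2ccccc2OCC2=NCCN2)c1` gives the highest of the three maxima in a functional assay with Alpha-1A adrenergic receptor (Homo sapiens) as the target, read by calcium flux (on this read-out higher numbers stand for larger maximal responses and lower numbers for smaller maximal responses), reaching 109%. Compound 2 `c1cnc(-c2ccccc2OCC2=NCCN2)nc1` gives 90%, and compound 3 `c1ccc(-c2ccsc2)c(OCC2=NCCN2)c1` gives 98%. Both replacements of the pyridin-3-yl group lowered the maximal response: a number 19 percentage points lower from compound 1 to compound 2 (beyond the scatter), and a number 11 percentage points lower from compound 1 to compound 3 (beyond the scatter). Between the two replacements themselves the numbers differ only within the scatter: a number 8 percentage points higher from compound 2 to compound 3 (within the scatter). Compound 4 `c1ccc(-c2cc[nH]n2)c(OCC2=NCCN2)c1` carries the change (1H-pyrazol-3-yl in place of pyridin-3-yl on an aromatic carbon). The two measured swaps at this carbon bear directly on it and both gave modest losses. Going by the values given here, no measured compound carries a five-membered ring with a hydrogen-bond donor at this position, so the range is kept wide. For compound 4 a modest drop is expected, a number 14 percentage points lower from compound 1 to compound 4 (beyond the scatter). Compound 4 is estimated at 95% in this assay, between 80% and 110%.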

Compound 4, largest response reached (reported as maximum), in percent of the reference or control that the assay uses: 119%
Beside the measured number, compound 4's estimate is 24 percentage points below it; the measured number lies above the stated range.
By their numbers in this assay, from the lowest: compounds 2 and 3 (each within the scatter of the next); then compounds 1 and 4 (each within the scatter of the next).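

On this aromatic carbon in this assay, 1H-pyrazol-3-yl is the one replacement of pyridin-3-yl shown that costs no maximal response, with a number 10 percentage points higher from compound 1 to compound 4 (within the scatter). It also stands clear of the other two replacements, with a number 21 percentage points higher from compound 3 to compound 4 (beyond the scatter) and a number 29 percentage points higher from compound 2 to compound 4 (beyond the scatter), so a five-membered aromatic ring alone does not set the response, as compound 3 shows. Nothing at hand explains these differences.

Open, from the compounds shown here alone, is whether the response holds with a methyl group on the pyrazole nitrogen in place of its hydrogen. Also open, going by these compounds, is how an aminomethyl group or a carboxylic acid would fare at this carbon.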